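Acetamido to (methylcarbamoyl)amino on the pyrrolidin-1-yl group

The compounds below may be only part of what the source reports. "The series", "measured", "known", "first", "only" and "open" are said of these compounds alone.

The series starts from compound 1 `O=C(CCc1ccc(C(F)(F)F)cc1)Nc1ccc2nc(N3CCC3)ccc2c1`, which in an assay on isolated protein for displacement of a labelled ligand from melanin-concentrating hormone receptor 1 (Homo sapiens) (on this read-out lower numbers stand for stronger inhibition and higher numbers for weaker inhibition), gives 4 nM. Compound 2 `CC(=O)NC1CCN(c2ccc3cc(NC(=O)CCc4ccc(C(F)(F)F)cc4)ccc3n2)C1` carries 3-acetamidopyrrolidin-1-yl in place of azetidin-1-yl on an aromatic carbon and in this assay gives 5 nM; the step of a 1.3-fold higher number from compound 1 to compound 2 (0.10 log units; within the scatter) lies within the scatter. Going by the values given here, compound 2 therefore stands at the highest of the two numbers so far, with compound 1 as its only neighbour, and the two values cannot be told apart.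

Compound 3 `CNC(=O)NC1CCN(c2ccc3cc(NC(=O)CCc4ccc(C(F)(F)F)cc4)ccc3n2)C1` is the next member. It differs from compound 2 by methylamino in place of methyl on a carbonyl carbon; cut one bond further out, this reads acetyl to methylcarbamoyl, or 3-acetamidopyrrolidin-1-yl to 3-((methylcarbamoyl)amino)pyrrolidin-1-yl.

Among the compounds with values here, no measured step touches this carbonyl carbon or the substituent on it. Within the data shown here, the one step in hand, from azetidin-1-yl to 3-acetamidopyrrolidin-1-yl, was within the scatter, so the read-out has so far been insensitive to what stands at this position. On that basis the expected step is no change at the digits printed from compound 2 to compound 3 (within the scatter), that is none beyond the scatter. Compound 3 is therefore estimated at 5 nM in this assay, within a range of 2 nM to 15 nM.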

Compound 3, half-maximal inhibitory concentration: 6 nM
Compound 3: the middle estimate sits 1.2-fold (0.08 log units) below what was measured, within the range that was stated.
By their numbers in this assay, from the lowest: compounds 1, 2 and 3 (each within the scatter of the next).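

Placing methylamino in place of methyl on a carbonyl carbon brings in one more heavy atom and one hydrogen-bond donor, yet this assay shows a 1.2-fold higher number from compound 2 to compound 3 (0.08 log units; within the scatter). Going by these compounds alone, this is the first measured change on the carbonyl carbon itself, and the read-out does not separate methyl from methylamino there, so acetamido and (methylcarbamoyl)amino cannot be told apart on the pyrrolidin-1-yl group. The comparison with the smaller group gives a 1.5-fold higher number from compound 1 to compound 3 (0.18 log units; within the scatter), so 3-((methylcarbamoyl)amino)pyrrolidin-1-yl, like 3-acetamidopyrrolidin-1-yl, cannot be told apart from azetidin-1-yl on the aromatic carbon, and no measurement at hand offers any explanation for this flat read-out.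

Open, as far as these compounds go, is how far this tolerance extends: all three compounds keep a neutral carbonyl-bearing or unsubstituted small ring group here, and the series says nothing yet of a free amine or a carboxylic acid on the pyrrolidin-1-yl group, or of a longer chain such as ethylamino or propylamino on the carbonyl carbon. From the compounds shown here alone, the rest of the structure is also the same in all three compounds, so the response to changes elsewhere, for instance to the trifluoromethyl group, remains unknown from these data.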